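Methoxy in Place of Hydroxy on Compound 3

This account rests on a few compounds, and the source may have more. Where it says the series, first, only, none or still open, it means among the compounds named here.

Compound 1, `N#Cc1cnc(NCc2cnccc2C(F)(F)F)cc1NC[C@H]1C[C@H](O)C1`, in an assay on isolated protein for inhibition of protein kinase C delta type (Homo sapiens), read by TR-FRET, with a stated time of 2 h (a lower number here means a stronger inhibitor, a higher number a weaker inhibitor), reaches only a limit of the assay, > 10000 nM.
Compound 2, `N#Cc1cnc(NCc2cnccc2C(F)(F)F)cc1N[C@H]1CC[C@H](O)CC1`, in this assay gives 6500 nM.
Compound 3, `N#Cc1cnc(NCc2cnccc2C(F)(F)F)cc1NC[C@H]1CC[C@H](O)CC1`, in this assay gives 2000 nM.

Compound 3 holds the lowest number of the two that were read out, with a 3.3-fold lower number from compound 2 to compound 3 (0.51 log units; beyond the scatter). Compound 4, `CO[C@H]1CC[C@@H](CNc2cc(NCc3cnccc3C(F)(F)F)ncc2C#N)CC1`, differs from compound 3 only in 4-methoxycyclohexyl in place of 4-hydroxycyclohexyl on a saturated chain carbon bound to a nitrogen on an aromatic ring. Among the compounds with values here, none of the measured steps touches this hydroxyl: an at least 1.5-fold lower number from compound 1 to compound 2 (0.18 log units; that floor lies within the scatter) and an at least 5.0-fold lower number from compound 1 to compound 3 (0.69 log units; beyond the scatter) change ring size and linker, not the oxygen. So no measured step bears on the change, and a small shift in either direction, or none beyond the scatter, is plausible. Compound 4 is expected to come in near 3500 nM, within 1000 nM to 12000 nM, an estimated 1.8-fold higher number from compound 3 to compound 4 (0.24 log units; within the scatter).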

Compound 4, half-maximal inhibitory concentration: 5000 nM
Estimate against measurement, compound 4: 1.4-fold (0.15 log units) below, and the stated range covers the measured number.
By their numbers in this assay, from the lowest: compound 3; then compounds 4 and 2 (each within the scatter of the next). At a limit, above all of these: compound 1.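

In this assay, the step of a 2.5-fold higher number from compound 3 to compound 4 (0.40 log units; beyond the scatter) shows that this hydroxyl is not a neutral site: 4-methoxycyclohexyl, with no hydrogen-bond donor, reads weaker than 4-hydroxycyclohexyl. The step of a 1.3-fold lower number from compound 2 to compound 4 (0.11 log units; within the scatter) leaves no clear gap between the two. Compound 1 stands only at a limit of the assay, so the step of an at least 2.0-fold lower number from compound 1 to compound 4 (0.30 log units; that floor lies within the scatter) gives nothing more than a floor.

No measurement shown gives a cause for the step from hydroxy to methoxy. From the compounds shown here alone, what an amine, a carboxylic acid or an ethoxy group would do in place of the hydroxyl stays open.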